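The source may hold more compounds than are shown below. What is called first, only, known or untested is meant among the compounds shown, and "the series" means these compounds.

Of the compounds shown here, three built on one shared core have been tested in a functional assay on MGC-803 cells (Homo sapiens) for antiproliferative activity, read by MTT assay, with a stated time of 72 h; a lower number here means a stronger inhibitor, a higher number a weaker inhibitor. Compound 1 `CCCSc1nc(N/N=C(\C)c2ccccc2O)c2nnn(Cc3ccc(Cl)cc3)c2n1` gives 7100 nM. Compound 2 `CCCSc1nc(N/N=C(\C)c2ccccc2O)c2nnn(Cc3ccccc3Cl)c2n1` gives 35000 nM, and the move a 4.9-fold higher number from compound 1 to compound 2 (0.69 log units; beyond the scatter) is the clearest difference among the three. Compound 3 `CCCSc1nc(N/N=C(\C)c2ccccc2O)c2nnn(Cc3ccc(O)cc3)c2n1` gives 7680 nM. On these numbers compound 3 sits alongside compound 1, since a 1.1-fold higher number from compound 1 to compound 3 (0.03 log units; within the scatter), while a 4.6-fold lower number from compound 2 to compound 3 (0.66 log units; beyond the scatter) separates it from compound 2.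

Compound 4 `CCCSc1nc(N/N=C(\C)c2ccccc2O)c2nnn(Cc3ccc(F)cc3)c2n1` has not yet been measured. It differs from compound 3 in a single place: fluoro in place of hydroxy on an aromatic carbon. Within the data shown here, the one measured step at this same position, swapping chloro for hydroxy, is a 1.1-fold higher number from compound 1 to compound 3 (0.03 log units; within the scatter), which stayed within the scatter. Among the measured compounds shown here, no measured step involves fluoro, so nothing here points to a large move in either direction. The expected step is therefore a 1.1-fold lower number from compound 3 to compound 4 (0.03 log units; within the scatter), not expected to reach beyond the scatter. Compound 4 is estimated at 7200 nM, with an expected range from 3500 nM to 15000 nM.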

Compound 4, half-maximal inhibitory concentration: 11000 nM
Beside the measured number, compound 4's estimate is 1.5-fold (0.18 log units) below it; low and high end bracket the measured number.
By their numbers in this assay, from the lowest: compounds 1, 3 and 4 (each within the scatter of the next); then compound 2.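

With fluoro as a third group on this aromatic carbon, the picture holds: there is a 1.4-fold higher number from compound 3 to compound 4 (0.16 log units; within the scatter) and a 1.5-fold higher number from compound 1 to compound 4 (0.19 log units; within the scatter), so hydroxy, chloro and fluoro cannot be told apart in this assay, even though only hydroxy carries a hydrogen-bond donor. The 2-chlorophenyl group remains apart from the 4-fluorophenyl group, with a 3.2-fold lower number from compound 2 to compound 4 (0.50 log units; beyond the scatter), a gap of the same kind as the one already seen with the other two groups. No outside evidence here explains why these three groups read alike.

As far as these compounds go, whether a larger or charged group on this carbon, such as an amine or a carboxylic acid, would stay in the same range remains open. From the compounds shown here alone, it is also open whether a 2-fluorophenyl group would read like the 2-chlorophenyl group.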